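Carbamate to nitrobenzamide on the sulfonamide aryl of compound 1

A few compounds are considered here, and "the series" means these few. Any claim that something is new, unique, unknown or untested is made for them only; others in the source may bear on it.

Measured compounds:
- compound 1 `CCOC(=O)Nc1ccc(S(=O)(=O)N2C(=O)N[C@@H](c3ccccc3)C2C)cc1Cl`: 6000 nM in a functional assay on NCI-H460 cells (Homo sapiens) for cytotoxicity, read by MTT assay; a lower number here means a stronger inhibitor, a higher number a weaker inhibitor
- compound 2 `CCOC(=O)Nc1ccc(S(=O)(=O)N2C[C@H](c3ccccc3)NC2=O)cc1Cl`: 20 nM in this assay
- compound 3 `CCOC(=O)Nc1ccc(S(=O)(=O)N2C(=O)N[C@@H](c3ccccc3)C2C)cc1C`: 5000 nM in this assay

Among these three, compound 1 gives the highest number in this assay; compound 3 sits nearest, a 1.2-fold lower number from compound 1 to compound 3 (0.08 log units; within the scatter), and compound 2 furthest, a 300-fold lower number from compound 1 to compound 2 (2.48 log units; beyond the scatter).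

Compound 4 `CC1[C@H](c2ccccc2)NC(=O)N1S(=O)(=O)c1ccc(NC(=O)c2ccc([N+](=O)[O-])cc2)c(Cl)c1` is not yet measured. It differs from compound 1 in one place: 4-nitrophenyl in place of ethoxy on a carbonyl carbon. Neither measured step touches this position. The step from compound 1 to compound 2 concerns the methyl on the saturated ring carbon, and the step from compound 1 to compound 3 concerns the aromatic chloro; both leave the carbamate intact, and the carbamate is retained in all three measured compounds. Among the measured compounds shown here, no measured step therefore bears on the change in compound 4, and no direction can be read from the data. The working expectation for compound 4 is a number near that of compound 1, no change at the digits printed from compound 1 to compound 4 (within the scatter), with a wide range to reflect the absence of any comparable step. The estimate for compound 4 in this assay is 6000 nM, between 1200 nM and 30000 nM.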

Compound 4, half-maximal inhibitory concentration: > 10000 nM
Compound 4 gave a limit, no number; the forecaster's own chance of this, stated with the estimate: 10%; middle value at least 1.6-fold (0.22 log units) away from the limit.
By their numbers in this assay, from the lowest: compound 2; then compounds 3 and 1 (each within the scatter of the next). At a limit, above all of these: compound 4.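

In this assay compound 4 gives only a limit of the assay, not a number: the limit of > 10000 nM in this assay, at which 1 of the 4 values shown sits. The change at the carbonyl carbon gives an at least 1.6-fold higher number from compound 1 to compound 4 (0.22 log units; that floor lies within the scatter), so a rise beyond the scatter is neither shown nor excluded. What compounds 1, 2 and 3 could not show, all three keeping the ethoxy group, is that 4-nitrophenyl at this carbonyl carbon brings no lower number.

The single change removes the ethoxy group and introduces both a phenyl ring and a nitro group, and the compounds shown do not separate the parts of that change. Still open, from the compounds shown here alone, are how methoxy, butoxy or an unsubstituted phenyl would read at this carbonyl carbon, and whether 4-nitrophenyl would behave the same way on the core of compound 2.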